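Aryl for propyl on the triazole ring: cytotoxicity expectation

This account rests on a few compounds, and the source may have more. Where it says the series, first, only, none or still open, it means among the compounds named here.

Compound 1 `COc1nc2ccc(Br)cc2cc1C(c1ccccc1)n1cc(-c2ccc(Br)cc2)nn1` gives 13.4% in an ADME assay on SK-OV-3 cells (Homo sapiens) for cytotoxicity, read by sulforhodamine B assay, with a stated time of 48 h, tested at 10 uM; on this read-out lower numbers stand for less inhibition and higher numbers for more inhibition at the one concentration tested (going by the name of the read-out); compound 2 `CCCc1cn(C(c2ccccc2)c2cc3cc(Br)ccc3nc2OC)nn1` gives 11.2%.

Compound 2 stands alongside compound 1: the step of a number 2.2 percentage points lower from compound 1 to compound 2 (within the scatter) lies within the scatter, so the two cannot be told apart. Compound 3 `COc1nc2ccc(Br)cc2cc1C(c1ccccc1)n1cc(-c2ccc(OC(F)(F)F)cc2)nn1` differs from compound 2 by 4-(trifluoromethoxy)phenyl in place of propyl on an aromatic carbon. For the measured compounds named here, this is the one relevant step, and it changed nothing beyond noise when an aromatic ring left; bringing a related ring back is expected to change nothing beyond the scatter either, with a number 1.8 percentage points higher from compound 2 to compound 3 (within the scatter) as the expected step. Compound 3 is therefore estimated at 13%, between 3% and 27%.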

Compound 3, a percentage reported as inhibition, at one concentration (the size of the read-out at that concentration, not a potency): 14.8%
Compound 3: the middle estimate sits 1.8 percentage points below what was measured, within the range that was stated.
By their numbers in this assay, from the lowest: compounds 2, 1 and 3 (each within the scatter of the next).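

In this assay, 4-(trifluoromethoxy)phenyl in place of propyl adds an aromatic ring and a hydrogen-bond acceptor, yet the number stays within the scatter (a number 3.6 percentage points higher from compound 2 to compound 3 (within the scatter)). Trifluoromethoxy in place of bromo on that aromatic group also stays within the scatter (a number 1.4 percentage points higher from compound 1 to compound 3 (within the scatter)), so compounds 1, 2 and 3 cannot be told apart at this position. Nothing available offers an explanation for this flat result. On these data alone, whether an amine or a carboxylic acid on this aromatic carbon would shift the number beyond the scatter remains open.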